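The source may hold more compounds than are shown below. What is called first, only, known or untested is meant among the compounds shown, and "the series" means these compounds.

Measured so far in a functional assay on SW-620 cells (Homo sapiens) for antiproliferative activity, read by MTT assay, with a stated time of 24 h; on this read-out higher numbers stand for weaker inhibition and lower numbers for stronger inhibition:
Compound 1 `COc1ccc(/C=C/C(=O)c2ccc(OC)c3c2OC(C)(C)C=C3)c(F)c1` gives 6570 nM.
Compound 2 `COc1ccc(C(=O)/C=C/c2cccc(F)c2)c2c1C=CC(C)(C)O2` gives > 10000 nM, which is a limit of the assay rather than a number.
Compound 3 `COc1ccc(C(=O)/C=C/c2ccccc2)c2c1C=CC(C)(C)O2` gives > 10000 nM, again a limit and not a number.

Compound 3 therefore stands at the edge of what this assay can report, and it shares that position with one other compound, as the limit of > 10000 nM in this assay, at which 2 of the 3 values shown sit, shows. Only compound 1 carries a number here. The steps that touch compound 3 are an at least 1.5-fold higher number from compound 1 to compound 3 (0.18 log units; that floor lies within the scatter), whose floor lies within the scatter, and a step that the two limits leave unreadable from compound 2 to compound 3, which the two limits leave unreadable; the parallel step an at least 1.5-fold higher number from compound 1 to compound 2 (0.18 log units; that floor lies within the scatter) tells the same story.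

Compound 4 `COc1ccc(C(=O)/C=C/c2ccccn2)c2c1C=CC(C)(C)O2` differs from compound 3 by pyridin-2-yl in place of phenyl on a double-bonded chain carbon bound to a double-bonded chain carbon. Within the data shown here, none of the measured steps involves a pyridin-2-yl group, so no step speaks directly to this change; what bears on it is only that the shared core of compounds 2 and 3 with a phenyl or 3-fluorophenyl group sat at the limit, and that the 2-fluoro-4-methoxyphenyl analogue reached a number barely beyond the scatter from that limit.

Compound 4 is therefore expected to remain near the limit, at an estimated 15000 nM (range 5000 nM to 50000 nM), the expected step being a step that the limit leaves unreadable from compound 3 to compound 4.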

Compound 4, half-maximal inhibitory concentration: 5000 nM
Compound 4: middle estimate off by 3.0-fold (0.48 log units), on the high side; the measured number falls inside the stated range.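

In this assay compound 4 carries a number, so a pyridin-2-yl group at this place on the chain moves the series off the limit, something only the 2-fluoro-4-methoxyphenyl group of compound 1 had done before: the limit of > 10000 nM in this assay, at which 2 of the 4 values shown sit. Read as steps, the change gives an at least 2.0-fold lower number from compound 3 to compound 4 (0.30 log units; that floor lies within the scatter) and an at least 2.0-fold lower number from compound 2 to compound 4 (0.30 log units; that floor lies within the scatter); both are floors and not sizes, so the data show a departure from the limit without fixing how large it is. The remaining step is a 1.3-fold lower number from compound 1 to compound 4 (0.12 log units; within the scatter), so the pyridin-2-yl group and the 2-fluoro-4-methoxyphenyl group cannot be told apart on this read-out, and swapping a single ring carbon for nitrogen reaches the same range as the two added groups of compound 1.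

What a pyridin-3-yl, pyridin-4-yl or pyrimidin-2-yl group would give at this place stays open, so the compounds shown do not tell whether the place of the ring nitrogen matters. Also open, going by these compounds, is whether a fluoro or methoxy group on the pyridin-2-yl ring would carry the number beyond the scatter from compound 4.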